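From 3-aminophenyl to 3-aminopropyl on a shared core

The source may report more compounds than this note shows. Statements on the series, on what has been measured and on what is new or still open speak of the compounds shown alone.

Three compounds built on a shared core have been taken into a functional assay on HCT-116 cells (Homo sapiens) for cytotoxicity, read by MTT assay, with a stated time of 72 h; a higher number here means a weaker inhibitor, a lower number a stronger inhibitor. For compound 1 `N[C@H]1CC[C@H](Nc2c(C(=O)NCc3ccc(F)cc3)nc(N3CCCCS3(=O)=O)c3cccnc23)CC1` the result is > 10000 nM, which is a limit of the assay and not a number. For compound 2 `O=C(NCc1ccc(F)cc1)c1nc(NCCO)c2cccnc2c1O` the entry reads "not determined" (no result reported). For compound 3 `Nc1cccc(Nc2c(C(=O)NCc3ccc(F)cc3)nc(Br)c3cccnc23)c1` the result is > 10000 nM, again a limit and not a number. Compound 3 therefore stands at the limit of > 10000 nM in this assay, at which 2 of the 3 values shown sit, and it offers no exact starting value.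

The next compound, compound 4 `NCCCNc1c(C(=O)NCc2ccc(F)cc2)nc(Br)c2cccnc12`, departs from compound 3 in one place, with 3-aminopropyl in place of 3-aminophenyl on a nitrogen on an aromatic ring. Going by the values given here, no two measured compounds differ in one place only, so the series gives no measured step to serve as a guide. The expectation therefore rests on compound 3 and its limit of > 10000 nM. No step beyond the scatter is expected in this assay, and the estimate reads a number no higher from compound 3 to compound 4 (the limit leaves the size open). The assay may well report only a limit again. For compound 4 the expected value is 10000 nM, with an estimated range from 2500 nM to 40000 nM.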

Compound 4, half-maximal inhibitory concentration: > 20000 nM
Compound 4: a limit, no number; the forecaster's own chance of this, stated with the estimate: 65%; middle value at least 2.0-fold (0.30 log units) away from the limit.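

In this assay, going by these compounds alone, compound 3 and compound 4 both carry limits of the assay and not numbers, and no step between them can be read. The compounds shown leave open how 3-aminopropyl and 3-aminophenyl compare in this position, and whether any compound on the shared core reaches an exact value in this assay.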